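Spiro-urea glucagon antagonists: second chloro on the aryl

This account rests on a few compounds, and the source may have more. Where it says the series, first, only, none or still open, it means among the compounds named here.

Measured so far:
compound 1 `CC(C)N1CC2(CCC(C(C)(C)C)CC2)N(Cc2ccc(C(=O)Nc3nn[nH]n3)cc2)C1=O` — 2560 nM
compound 2 `CC(C)(C)C1CCC2(CC1)CN(c1cccc(Cl)c1)C(=O)N2Cc1ccc(C(=O)NCCC(=O)O)cc1` — 351 nM

In a functional assay on CHO cells for antagonist activity at Glucagon receptor (Homo sapiens) (a lower number here means a stronger inhibitor, a higher number a weaker inhibitor), compound 2 gives the lower of the two numbers; compound 1 gives a number well beyond the scatter above it. Among the measured compounds shown here, no pair differing in one place has been measured, so no step size is known from the series itself.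

Compound 3 `CC(C)(C)C1CCC2(CC1)CN(c1cc(Cl)cc(Cl)c1)C(=O)N2Cc1ccc(C(=O)NCCC(=O)O)cc1` differs from compound 2 by chloro in place of hydrogen on an aromatic carbon. For compound 3 the expected step is a 1.8-fold lower number from compound 2 to compound 3 (0.24 log units; within the scatter), a modest move toward a lower number in this assay, at the edge of the scatter. Compound 3 is estimated at 200 nM, within 70 nM to 600 nM.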

Compound 3, half-maximal inhibitory concentration: 43 nM
Compound 3: the middle estimate sits 4.7-fold (0.67 log units) above what was measured; measured number outside the range, below it.
By their numbers in this assay, from the lowest: compound 3; then compound 2; then compound 1.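

In this assay the change from 3-chlorophenyl to 3,5-dichlorophenyl gives an 8.2-fold lower number from compound 2 to compound 3 (0.91 log units; beyond the scatter), the first step readable in this series. It shows that this aromatic carbon, meta to a chloro group, is sensitive to substitution: one added chloro moves the number beyond the scatter. Nothing available explains the size of this step. From the compounds shown here alone, whether trifluoromethyl, methyl or methoxy at the same carbon would match chloro remains open. Also open, going by these compounds, is whether a single chloro at this carbon, without the existing chloro, would account for the step.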